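The source may hold more compounds than are shown below. What is called first, only, known or untested is meant among the compounds shown, and "the series" means these compounds.

Measured compounds:
compound 1 `Cc1cccc(C(=O)N2CCCC(C(=O)Nc3ccc(Cl)cc3)C2)c1`: 0%
compound 2 `O=C(Nc1cccc(OCCc2ccccn2)c1)C1CCCN(C(=O)c2cc(C(F)(F)F)cc(C(F)(F)F)c2)C1`: 5%
compound 3 `COc1cccc(C(=O)N2CCCC(C(=O)Nc3ccc(Cl)cc3)C2)c1`: 0%

In an ADME assay on PC-3 cells (Homo sapiens) for cytotoxicity, read by WST assay, tested at 100 uM (on this read-out higher numbers stand for more inhibition at the one concentration tested (going by the name of the read-out) and lower numbers for less inhibition), all three measured compounds sit near the bottom of the scale. Compound 2 carries the largest of the three numbers, yet its gaps to compound 1 and to compound 3 lie within the scatter of repeated measurements, so it cannot be set apart from either. Within the data shown here, the only step measured between compounds that differ in one place is no change at the digits printed from compound 1 to compound 3 (within the scatter), a change on an aromatic carbon that left the read-out where it was.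

Compound 4 `O=C(c1ccccc1)c1cccc(NC(=O)C2CCCN(C(=O)c3cc(C(F)(F)F)cc(C(F)(F)F)c3)C2)c1` is the next compound for this assay. It differs from compound 2 in one place: benzoyl in place of 2-(pyridin-2-yl)ethoxy on an aromatic carbon. Among the measured compounds shown here, no measured pair tests this swap itself. What the data offer is a single step of no size and a set of three values that all sit close to zero, so the step from compound 2 to compound 4 is expected to stay within the scatter, as no change at the digits printed from compound 2 to compound 4 (within the scatter). Compound 4 is therefore estimated at 5%, between 0% and 18%.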

Compound 4, a percentage reported as inhibition, at one concentration (the size of the read-out at that concentration, not a potency): 0%
Compound 4: the middle estimate sits 5 percentage points above what was measured; the measured number falls inside the stated range.
By their numbers in this assay, from the lowest: compounds 1, 3, 4 and 2 (each within the scatter of the next).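

At this position, on an aromatic carbon of a six-membered aromatic ring of carbon only and meta to a large group, this assay gives a number 5 percentage points lower from compound 2 to compound 4 (within the scatter) for benzoyl in place of 2-(pyridin-2-yl)ethoxy. The earlier compounds shown here showed only a small swap of methoxy for methyl, whereas this pair shows that a large group with a carbon-only aromatic ring and a carbonyl can replace one with a hetero atom in its ring and an ether oxygen, with no difference beyond the scatter. No measurement shown offers an explanation for this outcome.

The compounds shown leave open whether an amine or a carboxylic acid at this position would give a read-out beyond the scatter. They also leave open whether a much shorter group there, such as a single fluorine, would separate from compound 2.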